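The source may report more compounds than this note shows. Statements on the series, on what has been measured and on what is new or still open speak of the compounds shown alone.

Compound 3 `COC(=O)/C=C/c1cccc(N(Cc2ccc(-c3cccc(Cl)c3)cc2)C(=O)NC(C)C)c1` has the highest number of the three measured compounds in an assay on isolated protein with Bile acid receptor (Homo sapiens) as the target; on this read-out lower numbers stand for an effect already at smaller amounts and higher numbers for an effect only at larger amounts of compound: compound 3 gives 1400 nM. Compound 1 `COC(=O)/C=C/c1cccc(N(Cc2ccc(-c3ccc(N(C)C)cc3)cc2)C(=O)NC(C)C)c1` gives 162 nM in this assay, and compound 2 `COC(=O)/C=C/c1cccc(N(Cc2ccc(/C=C/C(=O)OC(C)(C)C)cc2)C(=O)NC(C)C)c1` gives 212 nM; the two steps of an 8.6-fold higher number from compound 1 to compound 3 (0.94 log units; beyond the scatter) and a 6.6-fold higher number from compound 2 to compound 3 (0.82 log units; beyond the scatter) set compound 3 apart from both, while a 1.3-fold higher number from compound 1 to compound 2 (0.12 log units; within the scatter) shows compound 1 and compound 2 with numbers that cannot be told apart.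

Compound 4 `COC(=O)/C=C/c1cccc(N(Cc2ccc(-c3c(OC)cccc3OC)cc2)C(=O)NC(C)C)c1` differs from compound 3 in one place: 2,6-dimethoxyphenyl in place of 3-chlorophenyl on an aromatic carbon. Within the data shown here, no measured step exchanges a 3-chlorophenyl for a 2,6-dimethoxyphenyl, so the only bearing evidence is indirect. The steps from compound 1 and compound 2 to compound 3 show that the 3-chlorophenyl is the weakest of the three groups tried at this position, and the two groups that gave lower numbers, the 4-(dimethylamino)phenyl and the 2-(tert-butoxycarbonyl)ethenyl, both carry hydrogen-bond acceptors, as the 2,6-dimethoxyphenyl does. On that basis a lower number is expected for compound 4, with a step of about a 2.8-fold lower number from compound 3 to compound 4 (0.45 log units; beyond the scatter), though less than a full return to the level of compound 1 is assumed, since the new group has not itself been measured. Compound 4 is therefore estimated at 500 nM in this assay, with a likely range from 150 nM to 2000 nM.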

Compound 4, half-maximal effective concentration: 561 nM
For compound 4 the middle estimate is 1.1-fold (0.05 log units) below the measured one; the range from low to high includes it.
By their numbers in this assay, from the lowest: compounds 1 and 2 (each within the scatter of the next); then compound 4; then compound 3.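

In this assay the step of a 2.5-fold lower number from compound 3 to compound 4 (0.40 log units; beyond the scatter) shows that the number at this position, para to a large group, can move down when one six-membered aromatic ring takes the place of another, so the high number of compound 3 does not hold for every aromatic group here. The steps of a 2.6-fold higher number from compound 2 to compound 4 (0.42 log units; beyond the scatter) and a 3.5-fold higher number from compound 1 to compound 4 (0.54 log units; beyond the scatter) show that the 2,6-dimethoxyphenyl still does not reach the level of the two lowest compounds, which places compound 4 on a separate middle level and shows that hydrogen-bond acceptors in the entering group do not by themselves bring the number down that far. Nothing measured here accounts for the order of these groups.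

The compounds shown leave open whether a plain phenyl or a phenyl with a single methoxy group would stand nearer to compound 3 or to compound 4 at this position. Also open is how a free carboxylic acid in place of the tert-butyl ester of compound 2 would compare in this assay with the groups shown.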